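This account rests on a few compounds, and the source may have more. Where it says the series, first, only, none or still open, it means among the compounds named here.

Compound 2 `Clc1ccc(Cc2nn3cc(-c4ccc(Br)cc4)nc3s2)cc1` stands at a limit: in an ADME assay on CCRF-CEM cells (Homo sapiens) for cytotoxicity, with a stated time of 72 h (on this read-out lower numbers stand for stronger inhibition and higher numbers for weaker inhibition), compound 2 gives > 250000 nM, a limit of the assay rather than a number. Compound 1 `Fc1ccc(-c2cn3nc(Cc4ccc(Cl)cc4)sc3n2)cc1` also gives only a limit, > 250000 nM. Going by the values given here, the single measured step, a step that the two limits leave unreadable from compound 1 to compound 2, is therefore not readable, and the limit of > 250000 nM in this assay, at which 2 of the 2 values shown sit, is all that the measured values show. Compound 3 `Cc1ccc(-c2cn3nc(Cc4ccc(Cl)cc4)sc3n2)cc1` differs from compound 2 by methyl in place of bromo on an aromatic carbon. Among the compounds with values here, no measured step bears readably on this change. For compound 3 the value expected in this assay is 250000 nM, range 60000 nM to 500000 nM, most likely again reported as a limit. The expected step of a number no higher from compound 2 to compound 3 (the limit leaves the size open) is none beyond the scatter.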

Compound 3, half-maximal inhibitory concentration: > 250000 nM
Compound 3 ended at the assay's limit; the forecaster's own chance of this, stated with the estimate: 85%; the middle value lies on the limit itself.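

No step among compound 1, compound 2 and compound 3 can be read, since all three stop at one limit: the limit of > 250000 nM in this assay, at which 3 of the 3 values shown sit.

The compounds shown leave open how fluoro, bromo and methyl on that aromatic carbon would compare as readable numbers.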